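The source may report more compounds than this note shows. Statements on the series, on what has been measured and on what is new or still open speak of the compounds shown alone.

Notes on the series. Among the measured compounds shown here, compound 1 `CCc1ccc(N(CC(C)C)S(=O)(=O)c2ccc3c(c2)C(O)CC(C2CCOCC2)O3)cc1` is the reference point; in a physicochemical assay for lipophilicity, at pH 7.4 (on this read-out lower numbers stand for lower lipophilicity and higher numbers for higher lipophilicity), compound 1 gives 4.12, the highest of the two numbers measured so far. For the measured compounds named here, its only measured neighbour is compound 2 `CCc1ccc(NS(=O)(=O)c2ccc3c(c2)C(O)CC(C2CCOCC2)O3)cc1`, which in this assay gives 2.59; the step from compound 1 to compound 2 is a number 1.53 log units lower from compound 1 to compound 2 (beyond the scatter), with hydrogen in place of isobutyl on the sulfonamide nitrogen.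

Compound 3 `Cc1ccc(N(CC(C)C)S(=O)(=O)c2ccc3c(c2)C(O)CC(C2CCOCC2)O3)c(C)c1` is the next compound. Its change from compound 1 is 2,4-dimethylphenyl in place of 4-ethylphenyl on a sulfonamide nitrogen. Going by the values given here, no measured step bears on this change: the one step known concerns the isobutyl group, which compound 3 keeps, whereas here the two structures have the same atoms joined differently. The expected step from compound 1 to compound 3 is therefore a number 0.02 log units lower from compound 1 to compound 3 (within the scatter), none beyond the scatter. For compound 3 the estimate in this assay is 4.1, expected within 3.8 to 4.4.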

Compound 3, distribution coefficient: 4.19
Beside the measured number, compound 3's estimate is 0.09 log units below it, and the stated range covers the measured number.
By their numbers in this assay, from the lowest: compound 2; then compounds 1 and 3 (each within the scatter of the next).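

In this assay, the exchange of 4-ethylphenyl for 2,4-dimethylphenyl on the sulfonamide nitrogen gives a number 0.07 log units higher from compound 1 to compound 3 (within the scatter) and so leaves the read-out unresolved from that of the reference compound. The earlier pair showed a large step at this nitrogen when isobutyl was lost; this pair shows that, with isobutyl kept, moving from one aryl group to another with the same count of heavy atoms does not produce a step beyond the scatter. No measurement at hand accounts for this result.

Open, on these data alone, is whether the same holds for aryl groups that differ in their atoms, such as a phenyl ring bearing a carboxylic acid or an amine. Also open, as far as these compounds go, is how a longer chain in place of isobutyl would read, and whether the loss of isobutyl gives a similar step with 2,4-dimethylphenyl present.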